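Cytotoxicity notes on the shared-core series, compound 3 to 4

The source may hold more compounds than are shown below. What is called first, only, known or untested is meant among the compounds shown, and "the series" means these compounds.

Measured so far in an ADME assay on U2OS cells (Homo sapiens) for cytotoxicity; a higher number here means that more compound is tolerated, a lower number that less compound is tolerated:
- compound 1 `CCSc1ccc(-c2nccc3[nH]c(C(C)(C)O)cc23)cc1`: 17200 nM
- compound 2 `CC(C)(O)c1cc2c(Cl)nccc2[nH]1`: 15500 nM
- compound 3 `CC(C)(O)c1cc2c(-c3ccc(C#N)cc3)nccc2[nH]1`: "not determined" (no result reported)

Compound 1 and compound 2 give values within the usual scatter of each other; nothing separates them. Compound 3 stands without a number in this assay, so its own position cannot be placed against either.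

Compound 4 `Cc1ccc(-c2nccc3[nH]c(C(C)(C)O)cc23)cc1` differs from compound 3 by methyl in place of cyano on an aromatic carbon. For the measured compounds named here, no measured pair isolates this change. In this assay no shift beyond the usual scatter is expected from it, and the estimate for compound 4 is anchored on compound 1 and compound 2 rather than on compound 3. Compound 4 is expected to give about 15000 nM, within 6000 nM to 40000 nM.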

Compound 4, half-maximal cytotoxic concentration: 38500 nM
Compound 4: the middle estimate sits 2.6-fold (0.41 log units) below what was measured, and the stated range covers the measured number.
By their numbers in this assay, from the lowest: compounds 2 and 1 (each within the scatter of the next); then compound 4.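

In this assay the series now shows a change at this aromatic carbon that moves the read-out beyond the scatter: a 2.2-fold higher number from compound 1 to compound 4 (0.35 log units; beyond the scatter) with methyl in place of ethylsulfanyl. For the compounds shown here, the step is modest, and it is the first one that can be read. Nothing available accounts for this step.

Compound 3 has no number, so cyano cannot be placed against methyl or ethylsulfanyl. On these data alone, whether an amine, a carboxylic acid or a longer chain on this carbon would follow the same direction remains open.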